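Bromo Added to a Core at the Assay Limit

The source may hold more compounds than are shown below. What is called first, only, known or untested is meant among the compounds shown, and "the series" means these compounds.

Compound 1 `C(=C/c1nc2ncccc2[nH]1)\c1ccccc1` was tested in an ADME assay on WI-38 cells (Homo sapiens) for antiproliferative activity, read by MTT assay, with a stated time of 72 h (on this read-out higher numbers stand for weaker inhibition and lower numbers for stronger inhibition), where compound 1 gives 3870 nM. Compound 2 `N#Cc1ccc(/C=C/c2nc3ncccc3[nH]2)cc1` differs by an at least 25-fold higher number from compound 1 to compound 2 (1.41 log units; beyond the scatter). In this assay compound 2 gives > 100000 nM, which is a limit of the assay and not a number. Compound 2 therefore sits at the limit of > 100000 nM in this assay, at which 1 of the 2 values shown sits. Compound 3 `N#Cc1ccc(/C=C/c2nc3ncc(Br)cc3[nH]2)cc1` differs from compound 2 by bromo in place of hydrogen on an aromatic carbon. Among the measured compounds shown here, no measured step involves a bromo change, and compound 2 itself has no exact number. Compound 3 is expected to remain near the limit, an expected step of a number no higher from compound 2 to compound 3 (the limit leaves the size open). The estimate for compound 3 is 100000 nM, between 20000 nM and 300000 nM.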

Compound 3, half-maximal inhibitory concentration: 6760 nM
The estimate for compound 3 lay 15-fold (1.17 log units) above the measured number, and the stated range ends above it.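

In this assay, bromo in place of hydrogen on an aromatic carbon, two atoms from the ring nitrogen, gives an at least 14-fold lower number from compound 2 to compound 3 (1.17 log units; beyond the scatter) in a compound that also carries the nitrile. Among the compounds shown here, this position on the shared core, unchanged in the earlier compounds, can therefore turn a compound at the assay limit into one with a measurable number. Going by these compounds, compound 2 gives a limit and not a number, so the full size of this step stays open: the limit of > 100000 nM in this assay, at which 1 of the 3 values shown sits.

On these data alone, whether bromo has a similar effect without the nitrile remains open. A chlorine atom or an amine at this position would test whether the change depends on bromo itself.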